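A Cyclic Amide at the Carbonyl of a Chromene Acid

A few compounds are considered here, and "the series" means these few. Any claim that something is new, unique, unknown or untested is made for them only; others in the source may bear on it.

Measured compounds, all in a functional assay for inhibition of nuclear factor NF-kappa-B complex (Homo sapiens); on this read-out higher numbers stand for weaker inhibition and lower numbers for stronger inhibition:
Compound 1 `COc1ccc2c(c1)OC(c1cc(OC)c(OC)c(OC)c1)C(C(=O)O)=C2` gives > 50000 nM, a limit of the assay.
Compound 2 `COc1ccc2c(c1)OC(c1cc(OC)c(OC)c(OC)c1)C(C(N)=O)=C2` gives > 50000 nM, a limit of the assay.
Compound 3 `COc1ccc2c(c1)OC(c1cc(OC)c(OC)c(OC)c1)C(C(=O)N(C)C)=C2` gives > 50000 nM, a limit of the assay.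

Compound 3 thus stands at the limit where all three measured values sit (the limit of > 50000 nM in this assay, at which 3 of the 3 values shown sit). The steps a step that the two limits leave unreadable from compound 1 to compound 2, a step that the two limits leave unreadable from compound 1 to compound 3 and a step that the two limits leave unreadable from compound 2 to compound 3 are all unreadable between two limits, so no size or direction can be drawn from them. Compound 4 `COc1ccc2c(c1)OC(c1cc(OC)c(OC)c(OC)c1)C(C(=O)N1CCCCC1)=C2` differs from compound 3 by piperidin-1-yl in place of dimethylamino on a carbonyl carbon. Among the measured compounds shown here, no measured step bears readably on this change. Compound 4 is therefore expected to give 80000 nM, within 20000 nM to 300000 nM, most likely again only as a limit. The step this estimate means, a step that the limit leaves unreadable from compound 3 to compound 4, is expected to stay unreadable.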

Compound 4, half-maximal inhibitory concentration: > 50000 nM
Compound 4: only a limit was reported; the forecaster's own chance of this, stated with the estimate: 85%; the middle value does not contradict the limit.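

In this assay compound 4, like compounds 1, 2 and 3, gives only a limit, so no step among these compounds can be read: the limit of > 50000 nM in this assay, at which 4 of the 4 values shown sit. The compounds shown leave open whether the group on the carbonyl carbon changes inhibition at all.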